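A Smaller Group in Place of the Fluorophenyl

A few compounds are considered here, and "the series" means these few. Any claim that something is new, unique, unknown or untested is made for them only; others in the source may bear on it.

Of the compounds shown here, two sharing the same core have been measured so far. In an assay on isolated protein for inhibition of 2-Hydroxyacid oxidase 2 (Homo sapiens), tested at 1 uM (on this read-out higher numbers stand for a stronger effect at the one concentration tested and lower numbers for a weaker effect), compound 1 `Cc1n[nH]c(C(=O)O)c1Cc1cccc(-c2cccc(F)c2)c1` gives 20%, the higher of the two numbers at hand. For the measured compounds named here, compound 2 `CCc1n[nH]c(C(=O)O)c1Cc1cccc(-c2ccc(F)cc2)c1` gives 5% in this assay, a number beyond the scatter below compound 1; the two differ in more than one place, so no single step between them can be read off.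

Compound 3 `Cc1n[nH]c(C(=O)O)c1Cc1cccc(C#N)c1` has not yet been measured. Compared with compound 1 the change is cyano in place of 3-fluorophenyl on an aromatic carbon. Since compound 1 already sits low in this assay, and the change removes most of a large group, a drop of modest size is expected, the step of a number 10 percentage points lower from compound 1 to compound 3 (within the scatter) going downward and possibly no larger than the scatter. Compound 3 is therefore estimated at 10% in this assay, within a range from 0% to 25%.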

Compound 3, a percentage reported as inhibition, at one concentration (the size of the read-out at that concentration, not a potency): 6%
The estimate for compound 3 lay 4 percentage points above the measured number, and the stated range covers the measured number.
By their numbers in this assay, from the lowest: compounds 2 and 3 (each within the scatter of the next); then compound 1.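

For the compounds shown here, replacing the 3-fluorophenyl with cyano gives the first single-change comparison at this position: in this assay there is a number 14 percentage points lower from compound 1 to compound 3 (beyond the scatter), so what sits on this aromatic carbon does affect the read-out, even though both compounds give small numbers at the one concentration tested. This single step cannot separate the loss of the ring from the arrival of the nitrile, since both happen in the same change. Nothing available explains the drop.

Open questions remain about which part of the 3-fluorophenyl matters. A plain phenyl ring without fluorine, or a small group with no ring such as methoxy or an amine, would show whether the ring itself or the fluorine carries the difference, and whether any other group at this place can raise the number.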